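The source may report more compounds than this note shows. Statements on the series, on what has been measured and on what is new or still open speak of the compounds shown alone.

Among the three compounds measured, compound 2 `Cc1ccc(/C=C2\S/C(=N\c3csc(-c4ccc(Cl)cc4)c3)NC2=O)cc1` gives the lowest number in a functional assay on MDA-MB-231 cells (Homo sapiens) for cytotoxicity, read by MTT assay, with a stated time of 72 h (on this read-out lower numbers stand for stronger inhibition and higher numbers for weaker inhibition), at 900 nM. Compound 1 `O=C1N/C(=N/c2csc(-c3ccc(Cl)cc3)c2)S/C1=C\c1ccccc1` gives 18000 nM in this assay, and compound 3 `O=C1N/C(=N/c2csc(-c3ccc(Cl)cc3)c2)S/C1=C\c1ccc(Br)cc1` gives 3500 nM. Both steps to compound 2 are beyond the scatter: a 20-fold lower number from compound 1 to compound 2 (1.30 log units; beyond the scatter), and a 3.9-fold higher number from compound 2 to compound 3 (0.59 log units; beyond the scatter); the step of a 5.1-fold lower number from compound 1 to compound 3 (0.71 log units; beyond the scatter) is also beyond it.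

Compound 4 `O=C1N/C(=N/c2csc(-c3ccc(Cl)cc3)c2)S/C1=C\c1ccccn1` differs from compound 2 in one place: pyridin-2-yl in place of 4-methylphenyl on a double-bonded chain carbon bound to a double-bonded ring carbon. Within the data shown here, two measured steps bear on this change, though neither covers it fully. The methyl group that leaves is the one whose arrival gave a 20-fold lower number from compound 1 to compound 2 (1.30 log units; beyond the scatter), so taking it away by itself would be expected to raise the number strongly. Among the measured compounds shown here, the ring nitrogen that enters has no measured counterpart here, so its own contribution is unknown. For the measured compounds named here, the only comparison available, a 3.9-fold higher number from compound 2 to compound 3 (0.59 log units; beyond the scatter), shows that replacing the methyl with a different group on this ring also raised the number. The expectation is therefore a rise in this assay, probably large, roughly back toward the number of compound 1, with the step of an 8.9-fold higher number from compound 2 to compound 4 (0.95 log units; beyond the scatter) expected. For compound 4 the estimate is 8000 nM, with a range from 2000 nM to 30000 nM.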

Compound 4, half-maximal inhibitory concentration: 10900 nM
Estimate against measurement, compound 4: 1.4-fold (0.13 log units) below; low and high end bracket the measured number.
By their numbers in this assay, from the lowest: compound 2; then compound 3; then compounds 4 and 1 (each within the scatter of the next).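

In this assay, the pyridin-2-yl ring of compound 4 and the unsubstituted phenyl ring of compound 1 cannot be told apart at this place on a double-bonded chain carbon bound to a double-bonded ring carbon, since a 1.7-fold lower number from compound 1 to compound 4 (0.22 log units; within the scatter) stays within the scatter. Compound 4 does stand apart from both rings that carry a group, with a 12-fold higher number from compound 2 to compound 4 (1.08 log units; beyond the scatter) and a 3.1-fold higher number from compound 3 to compound 4 (0.49 log units; beyond the scatter), so among these four compounds the lower numbers belong only to 4-methylphenyl and 4-bromophenyl, and swapping a ring carbon for nitrogen does not reproduce what those groups give. No measurement offered here explains these differences.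

The compounds shown leave open whether a pyridine ring would follow the phenyl series once it carries a methyl or a bromo group, and whether pyridin-3-yl or pyridin-4-yl would read like pyridin-2-yl. They also leave open how far the number moves with other groups on the phenyl ring in place of the methyl, such as a methoxy, an ethyl, an amine or a carboxylic acid.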